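Carbamoyl Replacing an Alkenyl Chain on the Ester Arm

This account rests on a few compounds, and the source may have more. Where it says the series, first, only, none or still open, it means among the compounds named here.

Three measured compounds share one core and differ only in the ester arm. In a functional assay on thoracic aorta for inhibition of Voltage-gated L-type calcium channel (Rattus norvegicus) (on this read-out higher numbers stand for weaker inhibition and lower numbers for stronger inhibition), compound 1 `CC1=NC(C)=C(C(=O)O)C(c2cccc(Cl)c2)/C1=C(\O)OC/C=C/C1CCCCC1` gives 3.7 nM, compound 2 `CC1=NC(C)=C(C(=O)O)C(c2cccc(Cl)c2)/C1=C(\O)OC/C=C/c1ccc(Cl)cc1` gives 5.8 nM, and compound 3 `CC1=NC(C)=C(C(=O)O)C(c2cccc(Cl)c2)/C1=C(\O)OC/C(C)=C/c1ccccc1` gives 2.8 nM. Compound 3 holds the lowest number of the three, separated from compound 1 by a 1.3-fold lower number from compound 1 to compound 3 (0.12 log units; within the scatter) and from compound 2 by a 2.1-fold lower number from compound 2 to compound 3 (0.32 log units; beyond the scatter). Compound 4 `CC1=NC(C)=C(C(=O)O)C(c2cccc(Cl)c2)/C1=C(\O)OCC(=O)Nc1ccccc1` carries phenylcarbamoyl in place of 1-methyl-2-phenylethenyl on a saturated chain carbon bound to an oxygen on an unsaturated carbon. The earlier changes at this place moved the read-out little, as a 1.6-fold higher number from compound 1 to compound 2 (0.20 log units; within the scatter) also shows, so a small shift is expected, estimated as a 2.1-fold higher number from compound 3 to compound 4 (0.33 log units; beyond the scatter). Compound 4 is therefore expected to reach about 6 nM, within 2 nM to 20 nM.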

Compound 4, half-maximal inhibitory concentration: 50 nM
Compound 4: the middle estimate sits 8.3-fold (0.92 log units) below what was measured; the measured number lies above the stated range.
By their numbers in this assay, from the lowest: compounds 3, 1 and 2 (each within the scatter of the next, the first and the last beyond it); then compound 4.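

Unlike the swaps among the alkenyl arms, phenylcarbamoyl at this place gives clearly weaker inhibition in this assay (an 18-fold higher number from compound 3 to compound 4 (1.25 log units; beyond the scatter)), and the other two comparisons agree (a 14-fold higher number from compound 1 to compound 4 (1.13 log units; beyond the scatter)) (an 8.6-fold higher number from compound 2 to compound 4 (0.94 log units; beyond the scatter)). The position therefore does not accept every arm, even though phenylcarbamoyl and 1-methyl-2-phenylethenyl both hold 9 heavy atoms and one aromatic ring. Phenylcarbamoyl also brings a hydrogen-bond donor and acceptor, but no evidence here connects these to the result. The compounds shown leave open whether the loss follows the amide hydrogen or the carbonyl. A methylated amide or a ketone arm would separate the two.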